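Chain Extension of Fluorinated Alcohols and Lipophilicity

The compounds below may be only part of what the source reports. "The series", "measured", "known", "first", "only" and "open" are said of these compounds alone.

Compound 1 `OCCC(F)CC(F)(F)F`: 0.84
Compound 2 `CCC(F)(F)CO`: 0.67
Compound 3 `OCC(F)CC(F)(F)F`: 0.6

Three small fluorinated alcohols have been measured in a physicochemical assay for lipophilicity, read by NMR; a lower number here means a more polar compound, a higher number a more lipophilic compound. In this assay compound 1 gives 0.84, compound 2 gives 0.67 and compound 3 gives 0.6. Compound 1 and compound 3 differ in one place: hydroxymethyl in place of hydroxy on a saturated chain carbon, two bonds along the chain from a fluorine atom. That change carried the step of a number 0.24 log units higher from compound 3 to compound 1 (within the scatter).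

Compound 4 `CCC(F)(F)CCO` has not yet been measured. It stands to compound 2 as compound 1 stands to compound 3: hydroxymethyl in place of hydroxy on a saturated chain carbon, two bonds along the chain from two fluorine atoms. The two place descriptions are not identical, since in compound 2 the change sits two bonds along the chain from two fluorine atoms, whereas in compound 3 it sits two bonds along the chain from a fluorine atom, so this is the same kind of change rather than the same change. The difference between the core of compound 2 and the core of compound 3 is not broken down here.

Compound 4 is therefore expected to lie a little higher than compound 2, with an estimated step of a number 0.25 log units higher from compound 2 to compound 4 (within the scatter) in this assay, resting on the measured step of a number 0.24 log units higher from compound 3 to compound 1 (within the scatter). The estimate for compound 4 is 0.92, within 0.65 to 1.2.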

Compound 4, partition coefficient: 0.92
Compound 4: middle estimate and measured number agree at the digits printed; low and high end bracket the measured number.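

The same kind of change, hydroxymethyl in place of hydroxy, gave a new step in this assay of a number 0.25 log units higher from compound 2 to compound 4 (within the scatter), close in size to the earlier step of a number 0.24 log units higher from compound 3 to compound 1 (within the scatter), so across these two cores the change carried over at nearly the same size. Both steps lie within the scatter, however, so neither shows a firm shift on its own, and two cores are too few to show that the change would behave alike on any other core in the series. Nothing measured here speaks to what lies behind these steps or their similar size.

The compounds shown leave open whether the same change would give a step of similar size in a longer chain, or on a chain carrying no fluorine atoms. They also leave open how the series would read with an amine or a carboxylic acid in place of the hydroxy.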